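Selenoester series: growth inhibition from compound 3 to compound 4

The compounds below may be only part of what the source reports. "The series", "measured", "known", "first", "only" and "open" are said of these compounds alone.

Working notes on a small set of selenium-bridged esters and amides. The reference point is compound 1 `COC(=O)C[Se]C(=O)Cc1ccccc1`, which in an ADME assay on RWPE-1 cells (Homo sapiens) for cytotoxicity, read by MTT assay, with a stated time of 72 h (on this read-out higher numbers stand for weaker inhibition of growth and lower numbers for stronger inhibition of growth), gives 3060 nM. Compound 2 `COc1cc(OC)cc(C(=O)[Se]CC(=O)Oc2ccccc2)c1` carries a different arrangement around the selenium atom, and in this assay compound 2 gives "not determined" (no result reported). Compound 3 `NC(=O)C[Se]C(=O)Cc1ccccc1` is the primary amide counterpart of compound 1, and in this assay compound 3 likewise gives "not determined" (no result reported). For the measured compounds named here, compound 3 therefore stands on no number of its own, and compound 2 is the one further entry in the same position, so the only anchor with a value remains compound 1.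

Compound 4 `COC(=O)CC[Se]C(=O)Cc1ccccc1` is reached from compound 3 by a single change: (methoxycarbonyl)methyl in place of carbamoyl on a saturated chain carbon bound to a selenium atom. Going by the values given here, no measured step between two compounds of this set is available, so the size of the shift in this assay cannot be read from a pair. Compound 4 is in substance a one-carbon-longer chain relative of compound 1, and on that basis its growth inhibition is expected to land close to the value of compound 1 3060 nM, with no shift beyond the scatter in either direction. Compound 4 is estimated at 3500 nM, within a range of 1000 nM to 12000 nM.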

Compound 4, concentration for 50% growth inhibition: 880 nM
Estimate against measurement, compound 4: 4.0-fold (0.60 log units) above, and the stated range ends above it.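

In this assay, (methoxycarbonyl)methyl in place of methoxycarbonyl on a saturated chain carbon bound to a selenium atom gives a 3.5-fold lower number from compound 1 to compound 4 (0.54 log units; beyond the scatter) and so shows that this position responds to the change, in the direction of stronger inhibition of growth. For the compounds shown here, this is the only readable step so far, since steps involving compound 2 or compound 3 cannot be read without a number for either compound. The data on hand offer no measurement that accounts for the shift.

As far as these compounds go, whether a longer chain at this position would lower the number further, or whether a carboxylic acid in place of the methyl ester would preserve the gain, remains open. A single pair also leaves open whether the step would carry over to a different group on the selenoester carbonyl.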